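A few compounds are considered here, and "the series" means these few. Any claim that something is new, unique, unknown or untested is made for them only; others in the source may bear on it.

For the measured compounds named here, compound 1 `CC(C)Cc1cc(CNS(=O)(=O)c2ccc(C(C)(C)C)cc2)nn1-c1ccccc1` is the only member of this small set with a number: in a functional assay on HeLa cells for antagonist activity at 5-hydroxytryptamine receptor 6 (Homo sapiens), read by HTRF and cAMP accumulation, with stated times of 10 min and 30 min (on this read-out lower numbers stand for stronger inhibition and higher numbers for weaker inhibition), compound 1 gives 8780 nM. Compound 2 `CC(C)Cc1cc(CNS(=O)(=O)c2ccccc2)nn1-c1ccccc1` has no result in this assay; for compound 2 the record reads "not determined" (no result reported), so its standing on this read-out is open. Compound 3 `CC(C)Cc1cc(CNS(=O)(=O)c2ccc3ccccc3c2)nn1-c1ccccc1` differs from compound 2 by naphthalen-2-yl in place of phenyl on a sulfonyl sulfur. Going by the values given here, no measured step exists between the measured compounds, so the size of the step in this assay cannot be read from data; a modest gain rather than a loss is expected, anchored on compound 1 at 8780 nM. For compound 3 the estimate in this assay is 3000 nM, within 500 nM to 20000 nM.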

Compound 3, half-maximal inhibitory concentration: 3300 nM
Compound 3: middle estimate off by 1.1-fold (0.04 log units), on the low side; the range from low to high includes it.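

On a sulfonyl sulfur, naphthalen-2-yl in place of 4-(tert-butyl)phenyl gives a 2.7-fold lower number from compound 1 to compound 3 (0.42 log units; beyond the scatter) in this assay. Compound 1 alone could not show that this position responds to a change of aryl group, or that a fused aromatic group keeps measurable inhibition there. The step from compound 2 to compound 3 cannot be read, and no measured evidence bears on the cause of the step from compound 1.

Open, going by these compounds, is how a quinoline, or a phenyl carrying an amine or a carboxylic acid, would read at this position.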